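Metabolic stability notes: amide and carbamate chain variants

A few compounds are considered here, and "the series" means these few. Any claim that something is new, unique, unknown or untested is made for them only; others in the source may bear on it.

Compound 1 `CCOC(=O)NC/C=C\CN(C)C[C@H]1O[C@@H](n2c(C)nc3c(N)ncnc32)[C@H](O)[C@@H]1O` is the ethoxycarbonyl carbamate of the series. In an ADME assay on microsomes from liver (Homo sapiens) for metabolic stability, read by LC-MS, using NADPH, tested at 1 uM (on this read-out lower numbers stand for a shorter-lived compound and higher numbers for a longer-lived compound), compound 1 gives > 1.5 h, which is a limit of the assay rather than a number. Compound 2 `Cc1nc2c(N)ncnc2n1[C@@H]1O[C@H](CN(C)C/C=C\CNC(=O)OC(C)C)[C@@H](O)[C@H]1O` differs from compound 1 by methyl in place of hydrogen on a saturated chain carbon bound to an oxygen next to a carbonyl group and a saturated chain carbon. In this assay compound 2 gives > 1.5 h, again a limit. The step that the two limits leave unreadable from compound 1 to compound 2 therefore cannot be read. Compound 3 `CCC(=O)NC/C=C\CN(C)C[C@H]1O[C@@H](n2cnc3c(N)ncnc32)[C@H](O)[C@@H]1O` carries a propanoyl amide on a second core; how the core of compound 3 differs from that of compound 1 is not broken down here. In this assay compound 3 gives > 1.5 h, also a limit. All three measured values sit at the limit of > 1.5 h in this assay, at which 3 of the 3 values shown sit.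

Compound 4 `CCCC(=O)NC/C=C\CN(C)C[C@H]1O[C@@H](n2cnc3c(N)ncnc32)[C@H](O)[C@@H]1O` differs from compound 3 by methyl in place of hydrogen on a saturated chain carbon, two bonds along the chain from a carbonyl carbon. This is the same kind of change as from compound 1 to compound 2, but its place differs: there the methyl enters on a saturated chain carbon bound to an oxygen next to a carbonyl group, here two bonds along the chain from a carbonyl carbon. Since every measured value is a limit, the step for compound 4 is expected to be a step that the limit leaves unreadable from compound 3 to compound 4. This expectation rests on compound 3 alone, whose value of > 1.5 h is a limit. Compound 4 is expected to give about 2.5 h, between 1 h and 6 h, and most likely to return only a limit again.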

Compound 4, half-life: > 1.5 h
Compound 4 gave a limit, no number (the forecaster's own chance of this, stated with the estimate: 70%); the middle value does not contradict the limit.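

In this assay compound 4 gives > 1.5 h, which is a limit and not a number. The step from compound 3 to compound 4 therefore cannot be read, and all values remain at one limit: the limit of > 1.5 h in this assay, at which 4 of the 4 values shown sit.

The compounds shown leave open how long these four compounds actually last, and whether either added methyl changes that.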